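The compounds below may be only part of what the source reports. "The series", "measured", "known", "first", "only" and "open" are said of these compounds alone.

Of the compounds shown here, three have been measured in a functional assay on the whole organism (strain Wistar) for inhibition, with Rattus norvegicus as the target, read by paw edema, with stated times of 30 min and 3 h, at a dose of 100 mg/kg by the oral route; on this read-out higher numbers stand for more inhibition at the one dose given (going by the name of the read-out) and lower numbers for less inhibition. Among the measured compounds shown here, compound 1 `COc1cc(C(=O)N(C)C)nn1-c1ccccc1` gives 47.5%, and compound 2 `CC(C)Oc1cc(C(=O)N(C)C)nn1-c1ccccc1` gives 43.9%; the only single-change step among the measured compounds, isopropyl in place of methyl on an oxygen on an aromatic ring, is a number 3.6 percentage points lower from compound 1 to compound 2 (within the scatter). Compound 3 `C=CCNC(=O)c1cc(OCCCC)n(-c2ccccc2)n1` gives 4.4%, the lowest of the three numbers, beyond the scatter below both compound 2 and compound 1.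

Compound 4 `CCCCOc1cc(C(=O)N2CCCC2)nn1-c1ccccc1` has not yet been measured. It differs from compound 3 in one place: pyrrolidin-1-yl in place of allylamino on a carbonyl carbon. For the measured compounds named here, no measured step changes the group on the carbonyl carbon, so nothing measured bears directly on this change. The step from compound 1 to compound 2 changes a different place and lies within the scatter, which only suggests that the alkoxy group matters little between those two. Compound 3 differs from compound 1 and compound 2 both in the alkoxy chain and in the amide, so its low number cannot be assigned to either change alone. Since compound 1 and compound 2 carry a carbonyl bearing no hydrogen-bond donor and score far higher than compound 3, a rise is expected but with wide uncertainty: the expected step is a number 23.6 percentage points higher from compound 3 to compound 4 (beyond the scatter). Compound 4 is therefore estimated at 28%, in the range 5% to 52%.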

Compound 4, a percentage reported as inhibition, in the whole organism at one dose (the size of the read-out at that dose, not a potency): 17.6%
Compound 4: the middle estimate sits 10.4 percentage points above what was measured; low and high end bracket the measured number.
By their numbers in this assay, from the lowest: compound 3; then compound 4; then compounds 2 and 1 (each within the scatter of the next).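

With the butoxy chain held fixed, the group on the carbonyl carbon proves to matter on its own: in this assay, pyrrolidin-1-yl in place of allylamino gives a number 13.2 percentage points higher from compound 3 to compound 4 (beyond the scatter), a modest gain in inhibition at the one dose tested. Among the compounds shown here, this is the first measured step at this place, and it changes several things at once, since the amide hydrogen and the double bond of the allyl group leave while a five-membered non-aromatic ring enters. Nothing measured here ties this step to any particular property of either group, so its cause remains unknown.

The compounds shown cannot say which of those changes carries the step: propylamino on the same carbonyl carbon would remove only the double bond, while piperidin-1-yl or morpholin-4-yl would show whether the size of the ring or an added ring oxygen changes the number. On these data alone, it also stays open whether a shorter or longer chain on the oxygen, such as ethoxy or hexyloxy, alters the result when pyrrolidin-1-yl stays in place.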